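One halogen swap in the series

The source may hold more compounds than are shown below. What is called first, only, known or untested is meant among the compounds shown, and "the series" means these compounds.

For the measured compounds named here, compound 1 `O=C1/C(=C/c2ccccc2)CCC/C1=C\c1cccc(Br)c1` in an assay on isolated protein for inhibition of Alpha glucosidase (Homo sapiens), with stated times of 5 min and 15 min, tested at 50 uM (on this read-out higher numbers stand for more inhibition at the one concentration tested (going by the name of the read-out) and lower numbers for less inhibition), gives 27.2%, the lowest of the two numbers measured so far. Compound 2 `O=C(/C=C(O)/C=C/c1cc(O)ccc1O)c1cc(O)ccc1O` in this assay gives 96.9%, a gap beyond the scatter; the two structures differ in more than one place, so the gap is noted and not read further. Compound 3 `O=C1/C(=C/c2ccccc2)CCC/C1=C\c1ccc(F)cc1` is not yet measured. It differs from compound 1 in one place: 4-fluorophenyl in place of 3-bromophenyl on a double-bonded chain carbon bound to a double-bonded ring carbon. Going by the values given here, no step between measured compounds sets a size for such a change; the expected step of a number 2.2 percentage points lower from compound 1 to compound 3 (within the scatter) is small, within the scatter, with no clear direction. Compound 3 is expected to give 25% in this assay, estimated within 10% to 45%.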

Compound 3, a percentage reported as inhibition, at one concentration (the size of the read-out at that concentration, not a potency): 34%
For compound 3 the middle estimate is 9 percentage points below the measured one; measured number inside the range.
By their numbers in this assay, from the lowest: compounds 1 and 3 (each within the scatter of the next); then compound 2.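

For the compounds shown here, putting 4-fluorophenyl in place of 3-bromophenyl on a double-bonded chain carbon bound to a double-bonded ring carbon gives a number 6.8 percentage points higher from compound 1 to compound 3 (within the scatter) in this assay and provides the first one-place step. At this position, the change does not separate the two compounds on this read-out. No available evidence bears on this result.

As far as these compounds go, the halogen and its ring position change together in this step, so their separate contributions remain open. Also open, from the compounds shown here alone, is what an amine or a carboxylic acid would do at this position.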